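The source may report more compounds than this note shows. Statements on the series, on what has been measured and on what is new or still open speak of the compounds shown alone.

Compound 1 `COc1ccc(OC)c(C(=O)/C=C/c2cc(Br)c(Br)n2C)c1` and compound 2 `COc1ccc(OC)c(C(=O)/C=C/c2cc(Br)c(Br)[nH]2)c1` share one core. In a functional assay on PA-1 cells (Homo sapiens) for cytotoxicity, read by MTT assay, with stated times of 6 h and 48 h (on this read-out lower numbers stand for stronger inhibition and higher numbers for weaker inhibition), compound 1 gives 800 nM, and compound 2 gives 420 nM. The step between them is a 1.9-fold lower number from compound 1 to compound 2 (0.28 log units; within the scatter), the change being (hydrogen in place of methyl on an aromatic nitrogen). Compound 3 `Cn1c(-c2cc(-c3ccc[nH]3)no2)cc(Br)c1Br` is built on another core, and the difference between the two cores is not broken down here. In this assay compound 3 gives only a limit, >= 100000 nM, namely (the limit of >= 100000 nM in this assay, at which 1 of the 3 values shown sits). Compound 4 `Brc1cc(-c2cc(-c3ccc[nH]3)no2)[nH]c1Br` differs from compound 3 by hydrogen in place of methyl on an aromatic nitrogen, the same change as between compound 1 and compound 2, made at the same place. The step from compound 3 to compound 4 is expected to be a number no higher from compound 3 to compound 4 (the limit leaves the size open) in this assay, resting on compound 1 and compound 2, whose step is a 1.9-fold lower number from compound 1 to compound 2 (0.28 log units; within the scatter). Compound 4 is therefore expected to give 100000 nM, between 30000 nM and 300000 nM, most probably again only as a limit.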

Compound 4, half-maximal inhibitory concentration: >= 100000 nM
Compound 4 was reported as a limit; the forecaster's own chance of this, stated with the estimate: 70%; the middle value sits exactly at the limit.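

Compound 3 and compound 4 both stand only as limits in this assay, so no step can be read between them: the limit of >= 100000 nM in this assay, at which 2 of the 4 values shown sit.

The compounds shown leave open how far hydrogen in place of methyl on an aromatic nitrogen moves the number on this core.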